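Shortening the Branch on the Propargylic Chain

This account rests on a few compounds, and the source may have more. Where it says the series, first, only, none or still open, it means among the compounds named here.

Compound 2 `CC(C)CC(C#Cc1cccc(C(=O)NCc2ccccc2C(F)(F)F)c1)N(O)C(N)=O` stands second highest among the measured compounds in an assay for inhibition of Polyunsaturated fatty acid 5-lipoxygenase (Homo sapiens), read by HPLC, with stated times of 15 min and 10 min (a lower number here means a stronger inhibitor, a higher number a weaker inhibitor), where compound 2 gives 600 nM. Its nearest neighbour is compound 1 `CC(C)C(C#Cc1cccc(C(=O)NCc2ccccc2C(F)(F)F)c1)N(O)C(N)=O`, which in this assay gives 500 nM; the furthest is compound 3 `COc1ccc(CNC(=O)c2cccc(C#CC(C)N(O)C(N)=O)c2)c(C(F)(F)F)c1`, which in this assay gives 1700 nM. The change from compound 2 to compound 4 `CCC(C#Cc1cccc(C(=O)NCc2ccccc2C(F)(F)F)c1)N(O)C(N)=O` is methyl in place of isopropyl on a saturated chain carbon, two bonds along the chain from an amide-type nitrogen and a triple-bonded carbon. Going by the values given here, the one measured step that touches this part of the molecule is a 1.2-fold higher number from compound 1 to compound 2 (0.08 log units; within the scatter), which exchanged one branched group for another on the same chain carbon and moved the number hardly at all. Among the compounds with values here, no measured pair isolates the loss of branching on this chain. The expectation rests on that single step alone. On this footing a step of a 1.2-fold higher number from compound 2 to compound 4 (0.07 log units; within the scatter) is expected, with no shift beyond the scatter foreseen in either direction. Compound 4 is therefore estimated at 700 nM in this assay, within a range of 300 nM to 1700 nM.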

Compound 4, half-maximal inhibitory concentration: 500 nM
Beside the measured number, compound 4's estimate is 1.4-fold (0.15 log units) above it, within the range that was stated.
By their numbers in this assay, from the lowest: compounds 1, 4 and 2 (each within the scatter of the next); then compound 3.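

In this assay, replacing isopropyl with methyl on the saturated chain carbon, which turns isobutyl into ethyl, gives a 1.2-fold lower number from compound 2 to compound 4 (0.08 log units; within the scatter) and so shows that this position also tolerates an unbranched group. Hydrogen in place of methyl on the saturated chain carbon bound to two saturated chain carbons gives no change at the digits printed from compound 1 to compound 4 (within the scatter) and links the ethyl group directly to isopropyl. Across isopropyl, isobutyl and ethyl on this carbon, branching therefore leaves the number within the scatter, and no measurement shown accounts for this.

Compound 3 differs from these compounds in more than one place and does not settle what a smaller group does here. Going by these compounds, whether a longer chain such as hexyl, a phenyl ring or an amine on this carbon would keep the number within the scatter remains open.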